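Fluoro for Bromo in Two Related Hydrazone Series

The compounds below may be only part of what the source reports. "The series", "measured", "known", "first", "only" and "open" are said of these compounds alone.

In a functional assay on the whole organism (Ear) for inhibition, with Mus musculus as the target, with a stated time of 30 min, at a dose of 100 mg/kg by the intraperitoneal route (on this read-out lower numbers stand for less inhibition and higher numbers for more inhibition at the one dose given (going by the name of the read-out)), compound 1 `O=C(/C=C/c1ccc(/C=N/NC(=O)c2ccncc2)cc1)c1ccc(F)cc1` gives 51.1% and compound 2 `O=C(/C=C/c1ccc(/C=N/NC(=O)c2ccncc2)cc1)c1ccc(Br)cc1` gives 55.7%. The change from compound 2 to compound 1, (fluoro in place of bromo on an aromatic carbon), made a step of a number 4.6 percentage points lower from compound 2 to compound 1 (within the scatter). Compound 3 `N=C(N)N/N=C/c1ccc(/C=C/C(=O)c2ccccc2Br)cc1` gives 78.3% in this assay; the difference between its core and that of compound 2 is not broken down here. Compound 4 `N=C(N)N/N=C/c1ccc(/C=C/C(=O)c2ccccc2F)cc1` has not yet been measured. It differs from compound 3 by fluoro in place of bromo on an aromatic carbon, the same kind of change as from compound 2 to compound 1, though here the place is ortho to a large group rather than para to a large group. In this assay a step of about a number 6.3 percentage points lower from compound 3 to compound 4 (within the scatter) is expected, resting on the earlier step of a number 4.6 percentage points lower from compound 2 to compound 1 (within the scatter). Compound 4 is therefore estimated at 72%, expected between 58% and 84%.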

Compound 4, a percentage reported as inhibition, in the whole organism at one dose (the size of the read-out at that dose, not a potency): 91.7%
Compound 4: middle estimate off by 19.7 percentage points, on the low side; measured number above the stated range.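

In this assay, fluoro in place of bromo on the ring of compound 3 gives a number 13.4 percentage points higher from compound 3 to compound 4 (beyond the scatter), so the earlier step does not carry over from one core to the other in size or in direction: the same change on two cores in this assay, a number 4.6 percentage points lower (within the scatter) from compound 2 to compound 1 and a number 13.4 percentage points higher (beyond the scatter) from compound 3 to compound 4, 18 percentage points apart, beyond the scatter of two such steps. The result shows that, across these two pairs, the step from one core is a poor guide to the step on the other. It does not show whether the core or the place of the change sets the difference, as the two pairs differ in both, and two pairs establish no rule for the series.

The compounds shown leave open how chloro, methoxy or an amine would fare at this place. They also leave open how the unsubstituted phenyl compares on either core.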